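The source may hold more compounds than are shown below. What is called first, only, known or untested is meant among the compounds shown, and "the series" means these compounds.

Measured in a functional assay on SH-SY5Y cells (Homo sapiens) for cytotoxicity, read by MTT assay, with a stated time of 48 h; on this read-out higher numbers stand for weaker inhibition and lower numbers for stronger inhibition:
- compound 1 `COc1cc(/C=C/C(=O)/C=C/c2nc3cc([N+](=O)[O-])ccc3n2C)ccc1O`: 4600 nM
- compound 2 `COc1ccc2c(c1)nc(/C=C/C(=O)/C=C/c1ccc(OC)c(O)c1)n2C`: 4800 nM
- compound 3 `COc1ccc(/C=C/C(=O)/C=C/c2nc3cc(Cl)ccc3n2C)cc1O`: 4800 nM

Compound 3, at 4800 nM, is level with compound 2 and within the scatter of compound 1, so the three values form one tight group in this assay.

The next change is nitro in place of chloro on an aromatic carbon, and it leads to compound 4 `COc1ccc(/C=C/C(=O)/C=C/c2nc3cc([N+](=O)[O-])ccc3n2C)cc1O`, not yet measured.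

For the measured compounds named here, one measured step bears directly on this position: no change at the digits printed from compound 2 to compound 3 (within the scatter), a swap of methoxy for chloro on the same aromatic carbon that stays within the scatter. Compound 1 also carries the nitro group, on a core with the methoxy and hydroxy groups arranged differently, and gives 4600 nM. Going by the values given here, with only three compounds, this is thin evidence, but nothing measured so far points to a large effect at this position.

No shift beyond the scatter is expected in this assay, and the estimated change is a 1.0-fold lower number from compound 3 to compound 4 (0.01 log units; within the scatter). For compound 4 the estimated value is 4700 nM, with an expected range of 2500 nM to 9000 nM.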

Compound 4, half-maximal inhibitory concentration: 8100 nM
Estimate against measurement, compound 4: 1.7-fold (0.24 log units) below; the measured number falls inside the stated range.
By their numbers in this assay, from the lowest: compounds 1, 2, 3 and 4 (each within the scatter of the next).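

In this assay this aromatic carbon now carries chloro, methoxy and nitro, and neither swap to nitro leaves the scatter: nitro in place of chloro gives (a 1.7-fold higher number from compound 3 to compound 4 (0.23 log units; within the scatter)) and nitro in place of methoxy gives (a 1.7-fold higher number from compound 2 to compound 4 (0.23 log units; within the scatter)). With nitro held fixed, 3-hydroxy-4-methoxyphenyl in place of 4-hydroxy-3-methoxyphenyl gives (a 1.8-fold higher number from compound 1 to compound 4 (0.25 log units; within the scatter)), so this second kind of change also shows no shift beyond the scatter. No measurement on hand speaks to what lies behind these values.

The compounds shown do not tell whether any group on this aromatic carbon can move the number beyond the scatter. From the compounds shown here alone, how an amine or a carboxylic acid in that place would read in this assay remains open.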